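This account rests on a few compounds, and the source may have more. Where it says the series, first, only, none or still open, it means among the compounds named here.

In an assay on HEK293 cells for displacement of a labelled ligand from Neuronal acetylcholine receptor; alpha3/beta4 (Homo sapiens), read by scintillation counting, with a stated time of 120 min (on this read-out lower numbers stand for stronger inhibition and higher numbers for weaker inhibition), compound 1 `Fc1ccc(-c2cn(C3CN4CCC3CC4)nn2)cc1` gives 8.5 nM, the higher of the two numbers recorded. Compound 2 `c1ccc(COc2cccc(-c3cn(C4CN5CCC4CC5)nn3)c2)cc1` gives 7.57 nM in this assay, and its gap to compound 1 lies within the usual scatter. Compound 3 `Fc1ccc(-c2cn([C@@H]3CN4CCC3CC4)nn2)cc1` is related to compound 1 as follows: the two compounds have the same atoms and bonds; at least one stereo element is drawn with a configuration in one of them and without one in the other: 1 of 3 stereo elements differ; a stereocentre at a saturated ring carbon is drawn without a configuration in compound 1 and S in compound 3. For the measured compounds named here, no pair of measured compounds shows a change of this kind, so the size of the step is not known from the numbers here. The expected step from compound 1 is a 1.2-fold lower number from compound 1 to compound 3 (0.08 log units; within the scatter), not beyond the scatter in either direction, though with a wide range. Compound 3 is therefore expected to give 7 nM in this assay, between 2.5 nM and 40 nM.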

Compound 3, inhibition constant: 3.09 nM
Compound 3: the middle estimate sits 2.3-fold (0.36 log units) above what was measured; the range from low to high includes it.
By their numbers in this assay, from the lowest: compound 3; then compounds 2 and 1 (each within the scatter of the next).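

In this assay, drawing the stereocentre at the saturated ring carbon as S goes with a 2.8-fold lower number from compound 1 to compound 3 (0.44 log units; beyond the scatter). This is the only step among these compounds, and it shows that the number at this position can shift while atoms and bonds stay the same. The comparison rests on one condition: the fact that one of compounds 1 and 3 is drawn with a defined configuration and the other without, at the place where they differ

The compounds shown leave open how the R configuration compares with the S configuration. They also leave open whether a similar step would appear with a nitrile in place of the fluorine.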